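A few compounds are considered here, and "the series" means these few. Any claim that something is new, unique, unknown or untested is made for them only; others in the source may bear on it.

In a functional assay on KB cells (Homo sapiens) for antiproliferative activity, read by sulforhodamine B assay, with a stated time of 3 days (on this read-out lower numbers stand for stronger inhibition of growth and higher numbers for weaker inhibition of growth), compound 1 `COc1ccc(NC(=O)c2cccc(Nc3ncc(F)c(Nc4ccc(F)cc4)n3)c2)cc1` gives > 10000 nM and that is a limit of the assay, not a number. Compound 2 `O=C(Nc1cccc(Nc2ncc(F)c(Nc3ccc(F)cc3)n2)c1)c1cnccn1` gives 23600 nM in the same test. Compound 3 `O=C(Nc1cccc(Nc2ncc(F)c(Nc3ccc(F)cc3)n2)c1)c1cccc([N+](=O)[O-])c1` gives 15100 nM and so stands level with compound 2 (a 1.6-fold lower number from compound 2 to compound 3 (0.19 log units; within the scatter)). Compound 4 `O=C(Nc1cccc(Nc2ncc(F)c(Nc3ccc(F)cc3)n2)c1)c1ccccc1` takes the nitro group off compound 3 (hydrogen in place of nitro on an aromatic carbon), leaving hydrogen in place of nitro on an aromatic carbon, meta to a large group. Two measured steps come close to this change. The first (a step that the limit leaves unreadable from compound 1 to compound 2) gives no size to work with. The second (a 1.6-fold lower number from compound 2 to compound 3 (0.19 log units; within the scatter)) exchanged pyrazin-2-yl for 3-nitrophenyl on a carbonyl carbon and stayed inside the scatter. For the measured compounds named here, no measured step removes a nitro group directly, so no step beyond the scatter is expected in this assay here. The expected change is small (a 1.1-fold higher number from compound 3 to compound 4 (0.05 log units; within the scatter)). Compound 4 is expected at 17000 nM (estimated range 8000 nM to 40000 nM).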

Compound 4, concentration for 50% growth inhibition: > 10000 nM
Compound 4 ended at the assay's limit; the forecaster's own chance of this, stated with the estimate: 30%; the middle value does not contradict the limit.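

Compound 4 gives > 10000 nM in this assay, and that is a limit of the assay, not a number. No size can be read for its steps from compound 1, compound 2 or compound 3. The compounds shown leave open how far hydrogen in place of nitro on compound 3 changes growth inhibition, if at all.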